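Working notes: side-chain hydroxyl in the shared core series

A few compounds are considered here, and "the series" means these few. Any claim that something is new, unique, unknown or untested is made for them only; others in the source may bear on it.

Measured so far in a functional assay on HL-60 cells (Homo sapiens) for antiproliferative activity, read by MTT assay; on this read-out higher numbers stand for weaker inhibition and lower numbers for stronger inhibition:
- compound 1 `CCC[C@@H]1O[C@H](COCc2ccccc2)[C@@H](OCc2ccccc2)[C@H](OCc2ccccc2)[C@@H]1O` — "not active" (no number reported)
- compound 2 `OCCC[C@@H]1O[C@H](COCc2ccccc2)[C@@H](OCc2ccccc2)[C@H](OCc2ccccc2)[C@H]1O` — 19300 nM
- compound 3 `CCC[C@H]1O[C@H](COCc2ccccc2)[C@@H](OCc2ccccc2)[C@H](OCc2ccccc2)[C@@H]1O` — "not active" (no number reported)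

In this assay, within the data shown here, compound 2 gives 19300 nM; it is the only compound of the three for which a number is reported at all. Compound 1 and compound 3 both come back without a number, and the fact that compounds 1 and 3 differ only in the configuration as drawn is the only thing that separates those two. Both of them carry a plain chain on the shared core, with no hydroxyl on it, while compound 2 carries the chain that ends in a hydroxyl.

Compound 4 `CC[C@@H]1O[C@H](COCc2ccccc2)[C@@H](OCc2ccccc2)[C@H](OCc2ccccc2)[C@H]1O` has not been measured. It is reached from compound 2 by hydrogen in place of hydroxymethyl on a saturated chain carbon, two bonds along the chain from a saturated ring carbon. After this change compound 4, like compound 1 and compound 3, carries a chain without a hydroxyl on the shared core, though a shorter one. Among the measured compounds shown here, no measured step matches this change, so the expectation rests on the contrast between compound 2 and the two compounds that gave no number.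

The expected step in this assay is a 3.1-fold higher number from compound 2 to compound 4 (0.49 log units; beyond the scatter), toward weaker inhibition and beyond the usual scatter. For compound 4 the estimate in this assay is 60000 nM, with a range from 20000 nM to 200000 nM, and a real chance that only a limit is reported.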

Compound 4, half-maximal inhibitory concentration: 8200 nM
Compound 4: the middle estimate sits 7.3-fold (0.86 log units) above what was measured; the measured number lies below the stated range.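

In this assay the change from 3-hydroxypropyl to ethyl gives a 2.4-fold lower number from compound 2 to compound 4 (0.37 log units; beyond the scatter), a modest step toward stronger inhibition. Compound 4 carries no hydroxyl on its chain and still gives a number, so a chain-end hydroxyl is not required for a measurable value at this position, and the contrast drawn earlier between compound 2 and the two compounds without a number cannot be read as a simple need for that hydroxyl. Nothing shown gives a cause for this step.

The compounds shown leave open whether the shorter chain or the missing hydroxyl carries the step, as the two go together in this one change. Also open, from the compounds shown here alone, is how an amine or a carboxylic acid at the end of the chain, or a longer plain chain such as butyl, would read at the same position on the shared core.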